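Aryl-to-pentyl swap on a brominated quinolinone

This account rests on a few compounds, and the source may have more. Where it says the series, first, only, none or still open, it means among the compounds named here.

For the measured compounds named here, compound 2 `COc1ccc(Cn2c(-c3ccc(C)cc3)c(Br)c(=O)c3cc([N+](=O)[O-])ccc32)cc1` is the weaker of the two measured members in an assay on isolated protein for inhibition of alkaline phosphatase, tissue-nonspecific isozyme (Bos taurus), read by spectrophotometry, with stated times of 7 min and 15 min; a higher number here means a weaker inhibitor, a lower number a stronger inhibitor. Compound 2 gives 4220 nM, whereas compound 1 `CCCCCc1cc(=O)c2cc([N+](=O)[O-])ccc2n1Cc1ccc(OC)cc1` gives 1510 nM; the gap between the two lies beyond the scatter, and compound 2 stands at the higher, weaker end of the pair. Going by the values given here, compound 1 and compound 2 differ in more than one place, so no single step between them can be separated out.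

Compound 3 `CCCCCc1c(Br)c(=O)c2cc([N+](=O)[O-])ccc2n1Cc1ccc(OC)cc1` is the unmeasured member. It differs from compound 2 in one place: pentyl in place of 4-methylphenyl on an aromatic carbon. Compound 3 therefore carries the pentyl chain of compound 1 together with the bromo group of compound 2. Because compound 1 gives 1510 nM with the pentyl chain in place, a move toward the lower, stronger side is expected for compound 3, though the bromo group retained from compound 2 leaves the size of that move uncertain. The expected step from compound 2 to compound 3 in this assay is a 1.9-fold lower number from compound 2 to compound 3 (0.28 log units; within the scatter), a modest gain. Compound 3 is estimated at 2200 nM, with a range from 800 nM to 6000 nM.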

Compound 3, half-maximal inhibitory concentration: 9510 nM
Compound 3: middle estimate off by 4.3-fold (0.64 log units), on the low side, and the stated range ends below it.
By their numbers in this assay, from the lowest: compound 1; then compound 2; then compound 3.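

In this assay the two single changes can now be read apart, and both move the number upward. Pentyl in place of 4-methylphenyl, on the aromatic carbon next to the ring nitrogen, gives a 2.3-fold higher number from compound 2 to compound 3 (0.35 log units; beyond the scatter) with the bromo group present, so at this position the pentyl chain does not bring the lower number seen for compound 1 once the bromo group is there, and the 4-methylphenyl group reads better in that setting. Bromo in place of hydrogen on the neighbouring aromatic carbon gives a 6.3-fold higher number from compound 1 to compound 3 (0.80 log units; beyond the scatter) and is the larger of the two steps, which leaves compound 3 as the weakest of the three, while nothing measured here accounts for either step.

Still open, as far as these compounds go, is whether the swap from 4-methylphenyl to pentyl runs in the same direction with hydrogen in place of the bromo group, and so whether the two changes act independently of each other at this site. Also open, from the compounds shown here alone, is how a chloro group in place of the bromo group, or a longer chain such as octyl or a carboxylic acid at the end of the pentyl chain, would read.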